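Moving a methyl around the aryl ring of compound 1

The source may hold more compounds than are shown below. What is called first, only, known or untested is meant among the compounds shown, and "the series" means these compounds.

Measured so far:
- compound 1, `CC#CC(CC(=O)O)c1ccc(OCc2ccn3cc(-c4cccc(C)c4)nc3c2)cc1`: 1510 nM
- compound 2, `CC#CC(CC(=O)O)c1ccc(OCc2ccc3nc(-c4ccc(F)cc4)cn3c2)cc1`: 623 nM

Within the data shown here, in an assay on isolated protein for agonist activity at Free fatty acid receptor 1 (Homo sapiens) (a lower number here means that less compound is needed, a higher number that more compound is needed for the effect), compound 1 gives 1510 nM, the highest of the two numbers; compound 2 gives 623 nM, a lower number beyond the usual scatter, but its core is joined differently, so no single step links the two. Compound 3, `CC#CC(CC(=O)O)c1ccc(OCc2ccn3cc(-c4ccc(C)cc4)nc3c2)cc1`, keeps the core of compound 1 and differs only here: 4-methylphenyl in place of 3-methylphenyl on an aromatic carbon. The same atoms are present, joined differently. Among the measured compounds shown here, no measured pair here shows what this change does, so the expected step from compound 1 to compound 3, a 1.5-fold lower number from compound 1 to compound 3 (0.18 log units; within the scatter), is estimated as a small shift toward a lower number, roughly at the edge of the scatter. Compound 3 is therefore expected to give about 1000 nM, with a range from 300 nM to 3500 nM.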

Compound 3, half-maximal effective concentration: 618 nM
The estimate for compound 3 lay 1.6-fold (0.21 log units) above the measured number; measured number inside the range.
By their numbers in this assay, from the lowest: compounds 3 and 2 (each within the scatter of the next); then compound 1.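

In this assay, moving the methyl group from 3-methylphenyl to 4-methylphenyl gives a 2.4-fold lower number from compound 1 to compound 3 (0.39 log units; beyond the scatter), a step beyond the scatter although no atom is added or removed. Among these compounds, this shows that, at this aromatic carbon of the five-membered ring, the number depends on how the same atoms are arranged on the aryl ring, and not only on which atoms are present; no earlier pair of compounds differing in one place could show this. Nothing measured here explains why 4-methylphenyl gives the lower number.

Still open, from the compounds shown here alone, is how a plain phenyl, a 2-methylphenyl or a 4-methoxyphenyl would compare at this position. It is also unknown whether moving the methyl group would give a similar step on the core of compound 2.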